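The source may report more compounds than this note shows. Statements on the series, on what has been measured and on what is new or still open speak of the compounds shown alone.

Compound 2 `CNC(=O)CSc1nc2ccc(NC(=O)c3ccc([N+](=O)[O-])cc3)cc2s1` and compound 3 `O=C(CSc1nc2ccc(NC(=O)c3ccc([N+](=O)[O-])cc3)cc2s1)NCc1ccccc1` share a core, and compound 1 `O=C(CSc1nc2ccc(NC(=O)CCl)cc2s1)NCc1ccccc1` stands beside them. In a functional assay on HepG2 cells (Homo sapiens) for cytotoxicity, read by MTT assay, with a stated time of 48 h (on this read-out lower numbers stand for stronger inhibition and higher numbers for weaker inhibition), compound 2 gives > 100000 nM, which is a limit of the assay and not a number (the limit of > 100000 nM in this assay, at which 1 of the 2 values shown sits). Compound 1 gives 1100 nM in this assay. The change from compound 2 to compound 3 is phenyl in place of hydrogen on a saturated chain carbon bound to an amide-type nitrogen. Among the compounds with values here, no measured pair shows this step, so its size is open; a move toward stronger inhibition beyond the scatter is expected, though a further limit remains likely. Compound 3 is expected at 60000 nM, between 10000 nM and 200000 nM. The expected step is an at least 1.6-fold lower number from compound 2 to compound 3 (0.22 log units; that floor lies within the scatter).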

Compound 3, half-maximal inhibitory concentration: > 100000 nM
Compound 3: a limit, no number (the forecaster's own chance of this, stated with the estimate: 60%); at least 1.6-fold (0.22 log units) between middle value and limit.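

In this assay the change from methyl to benzyl cannot be read, because compound 2 and compound 3 both stand at a limit of the assay and give no number: the limit of > 100000 nM in this assay, at which 2 of the 3 values shown sit. Benzyl on this chain carbon thus brings no measurable value while 4-nitrophenyl stays on the carbonyl carbon. With benzylcarbamoyl held in place, 4-nitrophenyl in place of chloromethyl goes with an at least 90-fold higher number from compound 1 to compound 3 (1.95 log units; beyond the scatter) and so the carbonyl carbon, not the chain carbon, is where a readable change appears.

As far as these compounds go, whether methylcarbamoyl alongside chloromethyl keeps a number stays open. So does what an amine or a longer chain in place of chloromethyl on the carbonyl carbon would give.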